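The source may hold more compounds than are shown below. What is called first, only, known or untested is meant among the compounds shown, and "the series" means these compounds.

Compound 1, `Cc1nc(C)n(CC(=O)N2CCN(c3sc(C(F)(F)F)nc3-c3nc4ccc(C5CCOCC5)cc4[nH]3)C[C@H]2C)n1`, is the stronger of the two compounds measured in a functional assay on Venous blood for antagonist activity at C-X-C chemokine receptor type 3 (Homo sapiens), read by flow cytometry, with a stated time of 30 min, in the presence of a further agent that is not named here; on this read-out lower numbers stand for stronger inhibition and higher numbers for weaker inhibition. In this assay compound 1 gives 123 nM, the lowest of the two numbers available, while compound 2, `Cc1nc(C)n(CC(=O)N2CCN(c3sc(C(F)(F)F)nc3-c3nc4ccc(C(C)(C)O)c(F)c4[nH]3)C[C@H]2C)n1`, gives 628 nM, a gap that lies beyond the usual scatter of the method. Among the compounds with values here, compound 2 differs from compound 1 in more than one place, so the two values show only that compound 1 inhibits more strongly in this assay; no single step between them can be separated out.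

Compound 3, `Cc1nc(C)n(CC(=O)N2CCN(c3sc(C(F)(F)F)nc3-c3nc4ccc(OC5CNC5)cc4[nH]3)C[C@H]2C)n1`, has not yet been measured. It differs from compound 1 in one place: (azetidin-3-yl)oxy in place of oxan-4-yl on an aromatic carbon. Within the data shown here, no step between measured compounds in this assay bears on this change, so the expectation rests on compound 1 alone, at 123 nM, and on the shift from a neutral six-membered ring to a four-membered ring that brings a hydrogen-bond donor. The step expected from this change, a 2.0-fold higher number from compound 1 to compound 3 (0.31 log units; beyond the scatter), is toward a somewhat higher number, of a size close to the edge of the scatter. Compound 3 is therefore estimated at 250 nM in this assay, with a range from 80 nM to 800 nM.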

Compound 3, half-maximal inhibitory concentration: 580 nM
Compound 3: middle estimate off by 2.3-fold (0.37 log units), on the low side; measured number inside the range.
By their numbers in this assay, from the lowest: compound 1; then compounds 3 and 2 (each within the scatter of the next).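

In this assay, within the data shown here, exchanging the oxan-4-yl group for (azetidin-3-yl)oxy gives a 4.7-fold higher number from compound 1 to compound 3 (0.67 log units; beyond the scatter) and is the only step here that isolates a change at one place, showing that the inhibition read in this assay responds to the group held at this position. The change is not a single feature: the entering group differs from oxan-4-yl in its four-membered ring, its ring nitrogen, its oxygen attached to the aromatic carbon and its hydrogen-bond donor, and all of these arrive together in compound 3. No measurement is available that explains why this step weakens inhibition.

The compounds shown leave open which of these features carries the step, and whether it would persist if only one of them changed. An (oxetan-3-yl)oxy group would keep the four-membered ring and the oxygen attachment while replacing the ring nitrogen with oxygen, and a piperidin-4-yl group would keep a six-membered ring while bringing in a ring nitrogen, so each would address a different part of that question.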